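This account rests on a few compounds, and the source may have more. Where it says the series, first, only, none or still open, it means among the compounds named here.

Compound 3 `COCCNC(=O)c1c(-c2ccc(OC)c(OC)c2)csc1N` gives 55% in an assay on isolated protein for inhibition of protein kinase C zeta type (Homo sapiens), with stated times of 1 h and 2.5 min, tested at 30 uM (a lower number here means less inhibition, a higher number more inhibition at the concentration tested (going by the name of the read-out)), the lowest of the three numbers measured. Compound 1 `COc1ccc(-c2csc(N)c2C(=O)OCc2ccccc2)cc1OC` gives 100% and compound 2 `COc1ccc(-c2csc(N)c2C(=O)OCc2cccc(C)c2)cc1OC` gives 67%. The steps among them are a number 33 percentage points lower from compound 1 to compound 2 (beyond the scatter), a number 45 percentage points lower from compound 1 to compound 3 (beyond the scatter) and a number 12 percentage points lower from compound 2 to compound 3 (beyond the scatter). Compound 4 `COc1ccc(-c2csc(N)c2C(=O)NCc2ccccc2)cc1OC` differs from compound 3 by phenyl in place of methoxymethyl on a saturated chain carbon bound to an amide-type nitrogen, giving benzylamino in place of (2-methoxyethyl)amino. Among the compounds with values here, this most nearly reverses a number 45 percentage points lower from compound 1 to compound 3 (beyond the scatter), except that compound 4 carries benzylamino where compound 1 carries benzyloxy, and no measured pair separates those two. A large rise is nevertheless expected, so that compound 4 is estimated to show a number 30 percentage points higher from compound 3 to compound 4 (beyond the scatter). For compound 4 the expected value in this assay is 85%, within a range of 60% to 100%.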

Compound 4, a percentage reported as inhibition, at one concentration (the size of the read-out at that concentration, not a potency): 43%
For compound 4 the middle estimate is 42 percentage points above the measured one; measured number below the stated range.
By their numbers in this assay, from the lowest: compound 4; then compound 3; then compound 2; then compound 1.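

In this assay, benzylamino in place of benzyloxy on the carbonyl carbon gives a number 57 percentage points lower from compound 1 to compound 4 (beyond the scatter) here, so the benzyl group alone does not keep the high number and the linking atom counts in this series. Phenyl in place of methoxymethyl on a saturated chain carbon bound to an amide-type nitrogen brings no rise, with a number 12 percentage points lower from compound 3 to compound 4 (beyond the scatter) on this side chain. The step to benzylamino from (3-methylbenzyl)oxy reads the same way, with a number 24 percentage points lower from compound 2 to compound 4 (beyond the scatter) for that change.

On these data alone, whether a longer chain such as 2-phenylethylamino or a carboxylic acid at the carbonyl carbon would sit with the amides or the esters remains open. No evidence at hand bears on these steps.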